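Pyrazin-2-yl for 4-methoxyphenyl: expected antiproliferative effect

The compounds below may be only part of what the source reports. "The series", "measured", "known", "first", "only" and "open" are said of these compounds alone.

Two members of the series have been measured so far. Compound 1 `COc1ccc(-c2c(C)nn(-c3nc(-c4ccc(Cl)c(Cl)c4)c(SC(C)C)s3)c2C(=O)O)cc1` and compound 2 `Cc1c(-c2cc(Cl)cc(Cl)c2)c(C(=O)O)nn1-c1nc(-c2cc(Cl)cc(Cl)c2)c(SC(C)C)s1` share the same core and differ in more than one place. In a functional assay on BJAB cells (Homo sapiens) for antiproliferative activity, with a stated time of 4 days (on this read-out higher numbers stand for an effect only at larger amounts of compound and lower numbers for an effect already at smaller amounts), compound 1 gives 2100 nM. In this assay compound 2 gives 2000 nM. Compound 1 holds the higher of the two numbers, but its gap to compound 2 lies within the usual scatter of repeated measurements, so the two cannot be ordered against each other. Within the data shown here, no measured pair differs in a single place, so no step size from is available.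

Compound 3 `Cc1nn(-c2nc(-c3ccc(Cl)c(Cl)c3)c(SC(C)C)s2)c(C(=O)O)c1-c1cnccn1` is the next candidate. It differs from compound 1 by pyrazin-2-yl in place of 4-methoxyphenyl on an aromatic carbon. Among the measured compounds shown here, both measured compounds carry a six-membered aromatic ring of carbon only at this position; a ring with 2 hetero atoms at the same place has no precedent here, and nothing measured constrains the step. The estimated step of a 1.2-fold higher number from compound 1 to compound 3 (0.08 log units; within the scatter) is expected to stay inside the scatter, with a wide band around it. Compound 3 is therefore expected to give about 2500 nM in this assay, with a range from 800 nM to 8000 nM.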

Compound 3, half-maximal effective concentration: 14000 nM
Estimate against measurement, compound 3: 5.6-fold (0.75 log units) below; the measured number lies above the stated range.
By their numbers in this assay, from the lowest: compounds 2 and 1 (each within the scatter of the next); then compound 3.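

In this assay, among these compounds, the aromatic carbon of the five-membered aromatic ring with 2 nitrogen proves sensitive to the ring it carries: pyrazin-2-yl in place of 4-methoxyphenyl gives a 6.7-fold higher number from compound 1 to compound 3 (0.82 log units; beyond the scatter), the first step that isolates a single place, and it lies beyond the scatter. This single exchange replaces a six-membered aromatic ring of carbon only with one holding 2 hetero atoms, removes the oxygen of the 4-methoxyphenyl group and lowers the heavy-atom count of the group, so the step belongs to the whole exchange and not to any one of these differences. Nothing available gives a measured reason for the step.

The compounds shown leave open whether the higher number follows the ring nitrogens or the absence of the methoxy group. Phenyl and pyridin-2-yl at this carbon would separate those two differences, and 5-methoxypyrazin-2-yl would show whether a methoxy group on the pyrazine ring changes the read-out.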